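A few compounds are considered here, and "the series" means these few. Any claim that something is new, unique, unknown or untested is made for them only; others in the source may bear on it.

Values in a functional assay on KB cells (Homo sapiens) for inhibition, read by sulforhodamine B assay, with a stated time of 72 h; on this read-out higher numbers stand for weaker inhibition and lower numbers for stronger inhibition:
- compound 1 `Cc1cc(=O)c2ccc(O)c(CN(Cc3ccccc3)Cc3ccccc3)c2o1`: 15.1 ug/mL
- compound 2 `COc1ccc(CN(Cc2ccc([N+](=O)[O-])cc2)Cc2c(O)ccc3c(=O)cc(C)oc23)cc1`: 24.4 ug/mL

Only these two measurements are available so far. Compound 2, at 24.4 ug/mL, lies within the scatter of compound 1, at 15.1 ug/mL, so this assay does not separate the two.

The next compound to be read is compound 3 `COc1ccc(CN(Cc2ccc(OC)cc2)Cc2c(O)ccc3c(=O)cc(C)oc23)cc1`. It is reached from compound 2 by one structural change: methoxy in place of nitro on an aromatic carbon. In words, methoxy takes the place of nitro on an aromatic carbon, para to a large group, so that a 4-nitrobenzyl becomes a 4-methoxybenzyl.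

Among the compounds with values here, no measured pair isolates this exchange, so the data offer no direct guide to its size or direction. The only reference is the range set by the two values in hand, which sit within the scatter of each other. No change beyond the scatter is therefore expected in this assay. The estimated step is small: a 1.2-fold lower number from compound 2 to compound 3 (0.09 log units; within the scatter).

For compound 3 the expected value is 20 ug/mL, with an estimated range of 9 ug/mL to 42 ug/mL.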

Compound 3, half-maximal inhibitory concentration: 17.8 ug/mL
Compound 3: the middle estimate sits 1.1-fold (0.05 log units) above what was measured; the range from low to high includes it.
By their numbers in this assay, from the lowest: compounds 1, 3 and 2 (each within the scatter of the next).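

Within the data shown here, compound 2 and compound 3 form the first measured pair that differs in one place, so the exchange of nitro for methoxy on an aromatic carbon, para to a large group, can now be read directly: in this assay it gives a 1.4-fold lower number from compound 2 to compound 3 (0.14 log units; within the scatter). A 4-nitrobenzyl and a 4-methoxybenzyl at this place are therefore not separated by this assay, even though the two groups differ in their heavy atoms, their hydrogen-bond acceptors and the double bond that nitro carries outside the aromatic ring. Nothing in hand bears on what lies behind this result.

On these data alone, whether an amine or a carboxylic acid at the same place, or a longer chain such as ethoxy, would move the number beyond the scatter remains open, since this single exchange spans only nitro and methoxy. Also open, as far as these compounds go, is whether the other 4-methoxybenzyl group of compound 2 and compound 3 tolerates such exchanges in the same way, as that group stays the same across this pair.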